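The compounds below may be only part of what the source reports. "The series", "measured", "known", "first", "only" and "open" are said of these compounds alone.

In a functional assay on K562 cells (Homo sapiens) for antiproliferative activity, read by sulforhodamine B assay, with a stated time of 72 h (a lower number here means a stronger inhibitor, a higher number a weaker inhibitor), the measured compounds read as follows:

compound 1 `O=C1CS/C(=N/Nc2nncc3ccccc23)N1c1ccccc1` gives 57 nM
compound 2 `Cc1cc(C)nc(NS(=O)(=O)c2ccc(Nc3nncc4ccccc34)cc2)n1` gives 4.9 nM
compound 3 `C(=C/c1ccccc1)\C(=N\Nc1nncc2ccccc12)c1ccccc1` gives 4.4 nM

Compound 3 has the lowest of these numbers, but its value lies within the usual scatter of the value of compound 2, so the two count as level. Compound 1 stands clearly higher, well beyond the scatter from compound 3.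

Compound 4 `Clc1ccc(C(/C=C/c2ccccc2)=N\Nc2nncc3ccccc23)cc1` is compound 3 with a single change chloro in place of hydrogen on an aromatic carbon in which chloro takes the place of hydrogen on an aromatic carbon. For the measured compounds named here, no measured pair here shows what such a change does, so no shift beyond the scatter is expected in this assay. The expected step of a 1.1-fold higher number from compound 3 to compound 4 (0.06 log units; within the scatter) is therefore small and its direction open. The estimate for compound 4 is 5 nM with an expected range from 1.5 nM to 18 nM.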

Compound 4, half-maximal inhibitory concentration: 6.9 nM
Estimate against measurement, compound 4: 1.4-fold (0.14 log units) below; the measured number falls inside the stated range.
By their numbers in this assay, from the lowest: compounds 3, 2 and 4 (each within the scatter of the next); then compound 1.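

In this assay, for the compounds shown here, the change from phenyl to 4-chlorophenyl gives the first step between compounds that differ in one place: a 1.6-fold higher number from compound 3 to compound 4 (0.20 log units; within the scatter). This aromatic carbon, para to a large group, therefore carries chloro instead of hydrogen with no change that can be told apart from ordinary repeat scatter. Nothing measured here bears on what chloro does at this position. Still open, as far as these compounds go, is whether a different group here, such as an amine, a carboxylic acid or a longer chain, would move the number beyond the scatter.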